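Removing the Acetyl Group from a Weak Pyridine Inhibitor

The compounds below may be only part of what the source reports. "The series", "measured", "known", "first", "only" and "open" are said of these compounds alone.

Compound 1 `CC(C)Oc1cc(-c2cncc(-c3cnn(C4COC4)c3)c2)ccc1C(N)=O`: 200 nM
Compound 2 `CC(=O)c1cncc(-c2ccc(C(N)=O)cc2)c1`: 8000 nM
Compound 3 `COc1cc(C(N)=O)ccc1-c1cccnc1`: 29300 nM

In an assay on cells for inhibition of MAP kinase-interacting serine/threonine-protein kinase 1 (Homo sapiens), read by mobility shift assay, with stated times of 10 min and 60 min, in the presence of a further agent that is not named here (a higher number here means a weaker inhibitor, a lower number a stronger inhibitor), compound 2 holds the second highest of the three numbers. Compound 3 lies nearest, with a higher number, beyond the scatter; compound 1 lies furthest away, with a much lower number. Compound 4 `NC(=O)c1ccc(-c2cccnc2)cc1` differs from compound 2 in one place: hydrogen in place of acetyl on an aromatic carbon. The only strong inhibitor here, compound 1, carries the largest substituents, while compound 3, with little beyond the shared core, is weakest, so a step toward a higher number, beyond the scatter, is expected. Compound 4 is expected to give 30000 nM, estimated between 10000 nM and 100000 nM. The expected step of a 3.8-fold higher number from compound 2 to compound 4 (0.57 log units; beyond the scatter) points toward a weaker inhibitor.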

Compound 4, half-maximal inhibitory concentration: 8800 nM
Beside the measured number, compound 4's estimate is 3.4-fold (0.53 log units) above it, outside the stated range (below it).
By their numbers in this assay, from the lowest: compound 1; then compounds 2 and 4 (each within the scatter of the next); then compound 3.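

In this assay the acetyl group turns out to make no visible difference at this carbon, two atoms from the ring nitrogen: with hydrogen in its place, the two compounds cannot be told apart (a 1.1-fold higher number from compound 2 to compound 4 (0.04 log units; within the scatter)). Hydrogen in place of methoxy, a change elsewhere on the shared core, does register (a 3.3-fold lower number from compound 3 to compound 4 (0.52 log units; beyond the scatter)). No measurement at hand explains either result.

As far as these compounds go, whether another group on this carbon, such as an amine or a carboxylic acid, would shift the number remains open. Also open is which of the substituents of compound 1 accounts for its much lower number.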